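A few compounds are considered here, and "the series" means these few. Any claim that something is new, unique, unknown or untested is made for them only; others in the source may bear on it.

Measured in a functional assay on KYSE-450 cells (Homo sapiens) for inhibition, read by MTT assay, with a stated time of 48 h; a lower number here means a stronger inhibitor, a higher number a weaker inhibitor:
Compound 1 `COc1ccc(CN(C(C)=O)c2cc(OC)c(OC)c(OC)c2)cc1O`: 160 nM
Compound 2 `COc1ccc(CN(C(=O)C(C)Br)c2cc(OC)c(OC)c(OC)c2)cc1O`: 160 nM
Compound 3 `COc1ccc(CN(C(=O)CCCl)c2cc(OC)c(OC)c(OC)c2)cc1O`: 110 nM

These three compounds share a core and differ only in the group on the carbonyl carbon. Compound 3, at 110 nM, lies within the usual scatter of both compound 1 and compound 2, so the numbers do not rank the three.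

The next compound is compound 4 `COc1ccc(CN(C(=O)/C=C/CBr)c2cc(OC)c(OC)c(OC)c2)cc1O`, which carries 3-bromoprop-1-en-1-yl in place of 2-chloroethyl on a carbonyl carbon.

For the measured compounds named here, three measured steps bear on this change, all made at the same place: no change at the digits printed from compound 1 to compound 2 (within the scatter), a 1.5-fold lower number from compound 1 to compound 3 (0.16 log units; within the scatter) and a 1.5-fold lower number from compound 2 to compound 3 (0.16 log units; within the scatter). Judged by the size of these steps, no change beyond the scatter is expected in this assay, and neither direction is favoured. Going by the values given here, the evidence has a clear limit, though: no measured compound carries the 3-bromoprop-1-en-1-yl group, so the range is kept wide.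

The expected step is a 1.2-fold lower number from compound 3 to compound 4 (0.09 log units; within the scatter).

The estimated value for compound 4 is 90 nM, with an expected range from 25 nM to 300 nM.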

Compound 4, half-maximal inhibitory concentration: 100 nM
Estimate against measurement, compound 4: 1.1-fold (0.05 log units) below; measured number inside the range.
By their numbers in this assay, from the lowest: compounds 4, 3, 1 and 2 (each within the scatter of the next).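

Adding a double bond to the group on the carbonyl carbon, in the form of 3-bromoprop-1-en-1-yl, leaves the result in this assay within the scatter: the step is a 1.1-fold lower number from compound 3 to compound 4 (0.04 log units; within the scatter). The same holds against the other two groups at this place, with a 1.6-fold lower number from compound 2 to compound 4 (0.20 log units; within the scatter) from 1-bromoethyl and a 1.6-fold lower number from compound 1 to compound 4 (0.20 log units; within the scatter) from methyl, so the four compounds still cannot be ranked and this position has so far tolerated a plain methyl, two saturated halogen-bearing chains and an unsaturated one without a change beyond the scatter. No supporting measurement is available that could explain why these different groups give such similar numbers.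

The compounds shown do not separate the double bond from the bromine, and a comparison with plain prop-1-en-1-yl, or with the chlorine counterpart of 3-bromoprop-1-en-1-yl, would be needed to do that. On these data alone, it also remains open whether a quite different group at this place, such as an amine, a carboxylic acid or a much longer carbon chain, would shift the number beyond the scatter.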